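The source may hold more compounds than are shown below. What is called first, only, known or untested is meant among the compounds shown, and "the series" means these compounds.

Three compounds have been measured in an ADME assay on MT4 cells (Homo sapiens) for cytotoxicity, read by MTT assay; a higher number here means that more compound is tolerated, a lower number that less compound is tolerated:

compound 1 `COC(=O)c1ccc(NC(=O)CSc2nncnc2-c2cccc3ccccc23)c(Br)c1` gives 173000 nM;
compound 2 `COC(=O)c1ccc(NC(=O)CSc2nncnc2-c2ccccc2Cl)c(Br)c1` gives 59000 nM;
compound 3 `Cc1ccc(NC(=O)CSc2nncnc2-c2cccc3ccccc23)c([N+](=O)[O-])c1` gives 147000 nM.

Compound 1 and compound 2 share a core and differ in one place: 2-chlorophenyl in place of naphthalen-1-yl on an aromatic carbon. This change gave a 2.9-fold lower number from compound 1 to compound 2 (0.47 log units; beyond the scatter), so less of compound 2 was tolerated than of compound 1. Compound 3 sits on a different core; how its core differs from that of compound 1 is not broken down here. Compound 3 and compound 1 lie within the usual scatter of each other, while compound 3 stands apart from compound 2.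

Compound 4 `Cc1ccc(NC(=O)CSc2nncnc2-c2ccccc2Cl)c([N+](=O)[O-])c1` has not yet been measured. It relates to compound 3 as compound 2 relates to compound 1: 2-chlorophenyl in place of naphthalen-1-yl on an aromatic carbon, at a place described in the same words both times, so this is the same change carried onto a second core. The expectation rests on one observed step only. A step of a 2.9-fold lower number from compound 3 to compound 4 (0.47 log units; beyond the scatter) is expected, because the same change gave a 2.9-fold lower number from compound 1 to compound 2 (0.47 log units; beyond the scatter). Compound 4 is therefore estimated at 50000 nM, with a range from 25000 nM to 110000 nM.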

Compound 4, half-maximal cytotoxic concentration: 158000 nM
Compound 4: the middle estimate sits 3.2-fold (0.50 log units) below what was measured, outside the stated range (above it).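

In this assay, going by these compounds alone, putting 2-chlorophenyl in place of naphthalen-1-yl gave a 1.1-fold higher number from compound 3 to compound 4 (0.03 log units; within the scatter), so on this core the swap produced no step that can be told apart from the normal spread of repeated measurements. Set beside the earlier result, the same swap did not behave alike on the two cores: the same change on two cores in this assay, a 2.9-fold lower number (0.47 log units; beyond the scatter) from compound 1 to compound 2 and a 1.1-fold higher number (0.03 log units; within the scatter) from compound 3 to compound 4, 3.2-fold (0.50 log units) apart, beyond the scatter of two such steps

This shows that, in these two pairs, the step seen on one core could not be carried over to the other, so the result from the first pair was a poor guide to the second. Within the data shown here, it does not show which difference between the cores matters, and with only one pair on each core it says nothing about how the swap would behave on a third.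

The compounds shown leave open how a plain phenyl or a cyclohexyl group would fare on the same aromatic carbon. They also leave open whether a carboxylic acid in place of the methyl ester of compound 1 would alter the step.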